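The compounds below may be only part of what the source reports. "The series", "measured", "known", "first", "only" and "open" are said of these compounds alone.

Series notes. In a functional assay on Jurkat cells (Homo sapiens) for activation, with a stated time of 24 h (a lower number here means that less compound is needed, a higher number that more compound is needed for the effect), compound 1 `Oc1ccccc1CNc1ccc(-c2ccccc2)cc1` gives 1820 nM. Going by the values given here, compound 2 `Oc1ccc(-c2ccc(NCc3ccccc3O)cc2)cc1` in this assay is reported as "not active" (no number reported), so no number stands for it and no step from it can be sized. Compound 3 `Oc1ccccc1CNc1ccc(-c2cccc(Cl)c2)cc1` carries 3-chlorophenyl in place of 4-hydroxyphenyl on an aromatic carbon. Among the compounds with values here, no measured step for this change exists in the set; a return to a measurable value is expected rather than a further loss, since the closest measured neighbour with a number is compound 1. Compound 3 is therefore estimated in this assay at 1500 nM, with a range from 400 nM to 6000 nM.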

Compound 3, half-maximal effective concentration: 6200 nM
Compound 3: the middle estimate sits 4.1-fold (0.62 log units) below what was measured, and the stated range ends below it.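

In this assay, the 3-chlorophenyl group keeps a measurable read-out at this position, which the 4-hydroxyphenyl group of compound 2 did not give. Chloro in place of hydrogen on an aromatic carbon still gives a 3.4-fold higher number from compound 1 to compound 3 (0.53 log units; beyond the scatter) and so does not improve on the unsubstituted phenyl. The step between compound 2 and compound 3 cannot be read, and no measurement at hand explains either difference.

As far as these compounds go, whether the loss in compound 2 follows from the hydroxyl group itself remains open. So does the outcome with a methoxy group or an amine on this ring.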